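A few compounds are considered here, and "the series" means these few. Any claim that something is new, unique, unknown or untested is made for them only; others in the source may bear on it.

Working notes on the series. Compound 1 `NC(=O)c1c(NC(=O)c2ccccc2Cl)sc2c1CCN(Cc1ccccc1Cl)C2` gives 4430 nM in a functional assay on MKN-74 cells (Homo sapiens) for antiproliferative activity, with a stated time of 24 h (on this read-out lower numbers stand for stronger inhibition and higher numbers for weaker inhibition), and compound 2 `NC(=O)c1c(NC(=O)c2ccccc2Cl)sc2c1CCN(C(=S)Nc1ccc(C(F)(F)F)cc1)C2` gives 7090 nM; the two numbers lie within the usual scatter of each other, so neither can be set apart. Compound 3 `NC(=O)c1c(NC(=O)c2ccccc2Cl)sc2c1CCN(C(=O)Nc1c(Cl)cccc1Cl)C2` has not yet been measured. It differs from compound 1 in one place: (2,6-dichlorophenyl)carbamoyl in place of 2-chlorobenzyl on an amine nitrogen in a ring. Compound 2 carries a related arylthiocarbamoyl group on the same nitrogen, so a change from compound 1 to compound 3 beyond the scatter is not expected. The estimate for compound 3 is 6000 nM (range 2500 nM to 15000 nM), a step of a 1.4-fold higher number from compound 1 to compound 3 (0.13 log units; within the scatter) expected.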

Compound 3, half-maximal inhibitory concentration: 24400 nM
Compound 3: the middle estimate sits 4.1-fold (0.61 log units) below what was measured, outside the stated range (above it).
By their numbers in this assay, from the lowest: compounds 1 and 2 (each within the scatter of the next); then compound 3.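

The group on the amine nitrogen in a ring does shift the read-out: in this assay, (2,6-dichlorophenyl)carbamoyl in place of 2-chlorobenzyl gives a 5.5-fold higher number from compound 1 to compound 3 (0.74 log units; beyond the scatter). This change alters the linking atoms and the chlorine count together, so the step cannot be assigned to either one alone. Nothing available bears on the reason for the step. The compounds shown leave open whether the carbamoyl link or the second chlorine carries the step. A 2-chlorophenylcarbamoyl group on the same nitrogen would separate the two.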